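Extending the chain on the ring amine of compound 1

The source may hold more compounds than are shown below. What is called first, only, known or untested is meant among the compounds shown, and "the series" means these compounds.

Measured compounds:
Compound 1, `CCCN1CCCN(c2nc3ccccc3n2CCOCC)CC1`, gives 8.4 nM.
Compound 2, `C=CCOCCn1c(N2CCCN(C)CC2)nc2ccccc21`, gives 10 nM.
Compound 3, `CCCCCCn1c(N2CCN(C)CC2)nc2ccccc21`, gives 26 nM.

These three compounds were all tested in a functional assay on ileum for inhibition of histamine H1 receptor (Cavia porcellus); on this read-out higher numbers stand for weaker inhibition and lower numbers for stronger inhibition. Among them, compound 1 gives the lowest number. Compound 2 lies so close to it that the two cannot be told apart by this assay, as their values fall within the usual scatter of repeated measurements. Compound 3 gives a clearly higher number than compound 1, a gap that goes beyond the scatter, so compound 3 inhibits less strongly than compound 1 on this read-out.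

The step considered here leads from compound 1 to compound 4, `CCCCCN1CCCN(c2nc3ccccc3n2CCOCC)CC1`, which has not yet been measured. The change is ethyl in place of hydrogen on a saturated chain carbon, three bonds along the chain from an amine nitrogen in a ring; read from one bond further out, it turns a propyl into a pentyl on that ring amine. The compounds at hand offer no direct comparison for such a change, since compound 2 carries a methyl on the same kind of ring nitrogen but also differs elsewhere.

Among the measured compounds shown here, with no measured step to lean on, the step of a 1.4-fold higher number from compound 1 to compound 4 (0.15 log units; within the scatter) is expected to be small and not clearly beyond the scatter, leaning if anything toward a slightly higher number. Compound 4 is therefore estimated at 12 nM, with a range from 4 nM to 40 nM.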

Compound 4, half-maximal inhibitory concentration: 7.4 nM
For compound 4 the middle estimate is 1.6-fold (0.21 log units) above the measured one; measured number inside the range.
By their numbers in this assay, from the lowest: compounds 4, 1 and 2 (each within the scatter of the next); then compound 3.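

In this assay, the step is a 1.1-fold lower number from compound 1 to compound 4 (0.06 log units; within the scatter), so turning the propyl on the ring amine into a pentyl leaves the number where it was, as far as this read-out can tell. Among the compounds shown here, this is the first pair in the set that differs in only one place, and it shows that adding an ethyl on this saturated chain carbon, three bonds along the chain from the amine nitrogen in the ring, brings no measurable loss or gain of inhibition, even though the change adds 2 carbon atoms. Nothing measured here speaks to why the number stays unchanged.

The compounds shown leave open how far this holds: a longer chain such as heptyl, a benzyl, or a chain ending in an amine or a carboxylic acid could give a very different number at this position. On these data alone, it also remains open whether the same propyl to pentyl change would read the same with the other side chains on the core, such as the hexyl of compound 3.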